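The source may hold more compounds than are shown below. What is called first, only, known or untested is meant among the compounds shown, and "the series" means these compounds.

Measured so far:
compound 1 `CCc1cccc(NC(=O)CSc2nc(Nc3ccccc3)c3ccccc3n2)c1`: 11000 nM
compound 2 `O=C(CSc1nc(Nc2ccccc2)c2ccccc2n1)Nc1ccc(F)cc1`: 9560 nM

Both readings come from a functional assay on PC-3 cells (Homo sapiens) for inhibition, read by MTT assay, with a stated time of 72 h; on this read-out higher numbers stand for weaker inhibition and lower numbers for stronger inhibition. Among the measured compounds shown here, compound 2 sits at the lower of the two numbers, though the only step between them, a 1.2-fold lower number from compound 1 to compound 2 (0.06 log units; within the scatter), was within the scatter. Compound 3 `O=C(CSc1nc(Nc2ccccc2)c2ccccc2n1)Nc1ccc([N+](=O)[O-])cc1` is the next member: nitro in place of fluoro on an aromatic carbon. For the measured compounds named here, only one measured step touches the amide-side aryl ring, and it was flat, so nothing here points to a sizeable move in this assay. Compound 3 is therefore expected to stay close to compound 2, with a 1.1-fold lower number from compound 2 to compound 3 (0.03 log units; within the scatter) as the estimated step, giving an expected 9000 nM within 3000 nM to 30000 nM.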

Compound 3, half-maximal inhibitory concentration: 25000 nM
Compound 3: the middle estimate sits 2.8-fold (0.44 log units) below what was measured; the measured number falls inside the stated range.
By their numbers in this assay, from the lowest: compounds 2 and 1 (each within the scatter of the next); then compound 3.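

In this assay the amide-side aryl ring is not flat after all: nitro in place of fluoro gives a 2.6-fold higher number from compound 2 to compound 3 (0.42 log units; beyond the scatter) as a step beyond the scatter, where the earlier change on this ring stayed within it. Against the 3-ethylphenyl ring, 4-nitrophenyl gives a 2.3-fold higher number from compound 1 to compound 3 (0.36 log units; beyond the scatter) in the same direction, so compound 3 reads as the weakest of the three. No evidence is available that bears on this loss of inhibition.

From the compounds shown here alone, whether an amine or a carboxylic acid on the same aromatic carbon would shift the number as nitro does remains open. So does whether the step depends on the group being para to the large group.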